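Fluoro in place of methyl: what to expect of compound 4

The compounds below may be only part of what the source reports. "The series", "measured", "known", "first", "only" and "open" are said of these compounds alone.

Measured so far in an ADME assay on HEK293 cells (Homo sapiens) for cytotoxicity, read by MTT assay, with a stated time of 72 h; on this read-out lower numbers stand for stronger inhibition and higher numbers for weaker inhibition:
compound 1 `O=C(CN1CCN(C(=O)c2ccc(F)cc2)CC1)N1CCN(CCCc2c[nH]c3ccccc23)CC1` gives 141000 nM
compound 2 `COc1ccc2[nH]cc(CCCN3CCN(C(=O)CN4CCN(C(=O)c5ccc(Br)cc5)CC4)CC3)c2c1` gives 80500 nM
compound 3 `COc1ccc2[nH]cc(CCCN3CCN(C(=O)CN4CCN(C(=O)c5ccc(C)cc5)CC4)CC3)c2c1` gives 147000 nM

Compound 3 stands at 147000 nM and lies within the scatter of both other compounds, so these three numbers cannot be ranked. Compound 4 `COc1ccc2[nH]cc(CCCN3CCN(C(=O)CN4CCN(C(=O)c5ccc(F)cc5)CC4)CC3)c2c1` has not yet been measured. It carries fluoro in place of methyl on an aromatic carbon, para to a large group, relative to compound 3 (fluoro in place of methyl on an aromatic carbon).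

Among the measured compounds shown here, only one measured step touches this place. That step is a 1.8-fold higher number from compound 2 to compound 3 (0.26 log units; within the scatter) with methyl in place of bromo, and it stayed within the scatter. Compound 1, which also bears a 4-fluorophenyl group but differs elsewhere in the core, gives 141000 nM and is likewise within the scatter of compound 3. For the measured compounds named here, no measured pair shows fluoro exchanged directly for methyl, so the evidence is thin, but nothing in it points to a large move in this assay. The expected step is a 1.3-fold lower number from compound 3 to compound 4 (0.11 log units; within the scatter) and it is not expected to go beyond the scatter. For compound 4 the estimated value is 115000 nM with an expected range from 60000 nM to 200000 nM.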

Compound 4, half-maximal inhibitory concentration: > 200000 nM
Compound 4 gave a limit, no number; the forecaster's own chance of this, stated with the estimate: 10%; middle value at least 1.7-fold (0.24 log units) away from the limit.
By their numbers in this assay, from the lowest: compounds 2, 1 and 3 (each within the scatter of the next). At a limit, above all of these: compound 4.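

In this assay, compound 4 gave a limit of the assay and not a number: the limit of > 200000 nM in this assay, at which 1 of the 4 values shown sits. Fluoro in place of bromo on this aromatic carbon gives an at least 2.4-fold higher number from compound 2 to compound 4 (0.39 log units; beyond the scatter), the only step shown at this position that clearly passes the scatter, which the exchange of methyl for bromo, a 1.8-fold higher number from compound 2 to compound 3 (0.26 log units; within the scatter), did not do, so the position can register a difference in this assay that the earlier compounds could not show. The other two steps are only floors: fluoro in place of methyl gives an at least 1.3-fold higher number from compound 3 to compound 4 (0.13 log units; that floor lies within the scatter), and methoxy in place of hydrogen on the other end of the molecule gives an at least 1.4-fold higher number from compound 1 to compound 4 (0.15 log units; that floor lies within the scatter), so neither exchange can yet be said to move the value beyond the scatter.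

From the compounds shown here alone, how far compound 4 lies past its limit stays open, and with it the true size of both of these steps. The compounds shown also leave open where chloro or an amine on this same aromatic carbon would fall in this assay, and whether any such group would fall outside the scatter of compound 2.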